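Removing the chloro on the fused ring: outlook for compound 4

This account rests on a few compounds, and the source may have more. Where it says the series, first, only, none or still open, it means among the compounds named here.

compound 1 `CC(C)NC1=NS(=O)(=O)c2cc(Cl)ccc2N1` — 36300 nM
compound 2 `CC(C)NC1=NS(=O)(=O)c2cc(Cl)c(Cl)cc2N1` — 2300 nM
compound 3 `CC(C)NC1=NS(=O)(=O)c2cc(Br)c(Cl)cc2N1` — 5600 nM

All three values come from a functional assay (aorta) with Rattus norvegicus as the target, with a stated time of 90 min, at 37 degrees C; on this read-out lower numbers stand for an effect already at smaller amounts and higher numbers for an effect only at larger amounts of compound. Compound 2 gives the lowest number, compound 1 the highest; the step of a 16-fold higher number from compound 2 to compound 1 (1.20 log units; beyond the scatter) is the larger of the two shown, the step of a 2.4-fold higher number from compound 2 to compound 3 (0.39 log units; beyond the scatter) the smaller.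

Compound 4 `CC(C)NC1=NS(=O)(=O)c2cc(Br)ccc2N1` is not yet measured. It differs from compound 3 by hydrogen in place of chloro on an aromatic carbon. The same change has been made once before, from compound 2 to compound 1, where it gave a 16-fold higher number from compound 2 to compound 1 (1.20 log units; beyond the scatter). The two cores differ by bromo in place of chloro on an aromatic carbon, so the surroundings are not identical: in compound 2 the leaving chloro sits ortho to a chloro group, in compound 3 ortho to a bromo group. The change to compound 4 is thus the same kind of change, not the same.

Among the measured compounds shown here, since the one earlier instance is large and beyond the scatter, a step of comparable size is expected: a 14-fold higher number from compound 3 to compound 4 (1.15 log units; beyond the scatter). For compound 4 the expected value in this assay is 80000 nM, within 25000 nM to 250000 nM. This estimate rests on compound 3 at 5600 nM and on the step of a 16-fold higher number from compound 2 to compound 1 (1.20 log units; beyond the scatter).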

Compound 4, half-maximal effective concentration: 4800 nM
Compound 4: middle estimate off by 17-fold (1.22 log units), on the high side, outside the stated range (below it).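

In this assay, hydrogen in place of chloro on the bromo core gives a 1.2-fold lower number from compound 3 to compound 4 (0.07 log units; within the scatter), so the large step seen on the chloro core does not carry over to this core: the same change on two cores in this assay, a 16-fold higher number (1.20 log units; beyond the scatter) from compound 2 to compound 1 and a 1.2-fold lower number (0.07 log units; within the scatter) from compound 3 to compound 4, 18-fold (1.27 log units) apart, beyond the scatter of two such steps. The bromo-for-chloro change likewise depends on its surroundings, with a 7.6-fold lower number from compound 1 to compound 4 (0.88 log units; beyond the scatter) on the core lacking the second chloro, and this step runs opposite in direction to the one on the core that keeps it: the same change on two cores in this assay, a 2.4-fold higher number (0.39 log units; beyond the scatter) from compound 2 to compound 3 and a 7.6-fold lower number (0.88 log units; beyond the scatter) from compound 1 to compound 4, 18-fold (1.27 log units) apart, beyond the scatter of two such steps. These four compounds show that the two changes do not add up independently in this series, but they form a single set of paired steps and do not show what lies behind the difference, or whether it extends to any other core.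

Open, from the compounds shown here alone, is how each core responds to fluoro, methyl or methoxy on the aromatic carbon that carries the leaving chloro. Also open, going by these compounds, is whether the same dependence holds when the amine carries a longer chain or a ring.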